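Trifluoromethyl for Methyl on the Pendant Phenyl Ring

A few compounds are considered here, and "the series" means these few. Any claim that something is new, unique, unknown or untested is made for them only; others in the source may bear on it.

Measured compounds:
compound 1, `COc1cc2c(Oc3ccc(NC(=O)c4nn(-c5ccccc5C)c(=O)cc4C)cc3F)ccnc2cc1OCCCN1CCCC1`, 1400 nM
compound 2, `COc1cc2c(Oc3ccc(NC(=O)c4nn(-c5ccccc5C)c(=O)cc4C)cc3F)ccnc2cc1OCCCN1CCCCC1`, 2810 nM
compound 3, `COc1cc2c(Oc3ccc(NC(=O)c4nn(-c5ccccc5C)c(=O)cc4C)cc3F)ccnc2cc1OCCCN1CCN(C)CC1`, 3790 nM

In a functional assay on HT-29 cells (Homo sapiens) for inhibition, read by MTT assay, with a stated time of 72 h (a lower number here means a stronger inhibitor, a higher number a weaker inhibitor), compound 3 gives the highest of the three numbers. Its distance to compound 1 is real, a 2.7-fold higher number from compound 1 to compound 3 (0.43 log units; beyond the scatter), whereas the gap to compound 2, a 1.3-fold higher number from compound 2 to compound 3 (0.13 log units; within the scatter), lies within the scatter, so compounds 2 and 3 cannot be separated. The step of a 2.0-fold higher number from compound 1 to compound 2 (0.30 log units; within the scatter) also stays within the scatter.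

Compound 4, `COc1cc2c(Oc3ccc(NC(=O)c4nn(-c5ccccc5C(F)(F)F)c(=O)cc4C)cc3F)ccnc2cc1OCCCN1CCN(C)CC1`, departs from compound 3 by trifluoromethyl in place of methyl on an aromatic carbon. All three measured steps concern the terminus of the saturated chain on the other side of the shared core; none of them touches the aromatic carbon where this change sits. Among the compounds with values here, there is therefore no measured step that bears on it, and the expectation rests on compound 3 alone.

Compound 4 is expected to give 3800 nM in this assay, with a range from 1500 nM to 9500 nM. This estimate means a step of a 1.0-fold higher number from compound 3 to compound 4 (0.00 log units; within the scatter), which is expected to stay within the scatter.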

Compound 4, half-maximal inhibitory concentration: 170 nM
For compound 4 the middle estimate is 22-fold (1.35 log units) above the measured one; the whole stated range lies above it.
By their numbers in this assay, from the lowest: compound 4; then compounds 1, 2 and 3 (each within the scatter of the next, the first and the last beyond it).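

In this assay the step of a 22-fold lower number from compound 3 to compound 4 (1.35 log units; beyond the scatter) shows that the group on this aromatic carbon, ortho to a large group, can move the number far more than the chain terminus did, where the widest step was a 2.7-fold higher number from compound 1 to compound 3 (0.43 log units; beyond the scatter) and the core stayed the same. The exchange of 2-methylphenyl for 2-(trifluoromethyl)phenyl brings this shift with no change in the counts of hydrogen-bond donors, hydrogen-bond acceptors, rings or net charge. Nothing in the information available accounts for the shift. 

The compounds shown leave open whether a chlorine atom, a methoxy group or an unsubstituted phenyl ring would give a similar number at this position. They also leave open whether trifluoromethyl gives the same gain when the chain ends in pyrrolidin-1-yl or piperidin-1-yl rather than 4-methylpiperazin-1-yl.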